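The source may hold more compounds than are shown below. What is called first, only, known or untested is meant among the compounds shown, and "the series" means these compounds.

In a functional assay on MDA-MB-435 cells (Homo sapiens) for inhibition, read by sulforhodamine B assay, with a stated time of 48 h (a higher number here means that more compound is needed for the effect, a lower number that less compound is needed), compound 2 `CCN(c1ccc(OC)cc1)c1ncnc2occ(C)c12` gives 8.1 nM, the lower of the two numbers available. Compound 3 `CCc1ccc(N(C)c2ncnc3occ(C)c23)cc1` gives 183 nM, a gap beyond the scatter, while compound 1 `CSc1ccc(Nc2ncnc3occ(C)c23)cc1` has no number, its result reading "not determined" (no result reported). Compound 4 `COc1ccc(N(C)c2ncnc3occ(C)c23)cc1` departs from compound 2 by a single change, hydrogen in place of methyl on a saturated chain carbon bound to a nitrogen on an aromatic ring, which turns ethyl to methyl. Within the data shown here, no measured pair isolates this change, so the expectation is loose: a small shift to a higher number in this assay, probably none beyond the scatter. The expected step is a 1.2-fold higher number from compound 2 to compound 4 (0.09 log units; within the scatter). Compound 4 is estimated at 10 nM, with an expected range from 3 nM to 35 nM.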

Compound 4, half-maximal effective concentration: 4.3 nM
Estimate against measurement, compound 4: 2.3-fold (0.37 log units) above; measured number inside the range.
By their numbers in this assay, from the lowest: compounds 4 and 2 (each within the scatter of the next); then compound 3.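

Within this assay, ethyl to methyl gives a 1.9-fold lower number from compound 2 to compound 4 (0.28 log units; within the scatter), so these two chains are not told apart at this position. Methoxy in place of ethyl on an aromatic carbon gives a 43-fold lower number from compound 3 to compound 4 (1.63 log units; beyond the scatter), which shows that the aromatic substituent, not the chain, carries the large difference among these compounds. Nothing measured here accounts for either step.

The compounds shown leave open whether a longer chain, such as propyl, would keep the number where it stands. They also leave open whether an amine or a hydroxyl group could replace methoxy on that aromatic carbon.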